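This account rests on a few compounds, and the source may have more. Where it says the series, first, only, none or still open, it means among the compounds named here.

Three compounds share one core. Compound 1 `CCCOC(=O)CCC(=O)N1CCN(CCCOc2cc3c(Nc4ccc(F)c(Cl)c4)ncnc3cc2OC)CC1` gives 23.4% in a functional assay on A549 cells (Homo sapiens) for cytotoxicity, read by MTT assay, with a stated time of 24 h, tested at 80 uM; a higher number here means a weaker effect of the compound at the concentration tested, a lower number a stronger effect. Compound 2 `CCCCCOC(=O)CCC(=O)N1CCN(CCCOc2cc3c(Nc4ccc(F)c(Cl)c4)ncnc3cc2OC)CC1` gives 18.2% in this assay, and compound 3 `CCCCCCCCOC(=O)CCC(=O)N1CCN(CCCOc2cc3c(Nc4ccc(F)c(Cl)c4)ncnc3cc2OC)CC1` gives 21.7% in this assay. Compound 3 stands second highest of the three numbers, with compound 1 nearest and compound 2 furthest, and every step among them stays within the scatter: a number 5.2 percentage points lower from compound 1 to compound 2 (within the scatter), a number 1.7 percentage points lower from compound 1 to compound 3 (within the scatter), a number 3.5 percentage points higher from compound 2 to compound 3 (within the scatter). Compound 4 `CCCCCCCCCCCCOC(=O)CCC(=O)N1CCN(CCCOc2cc3c(Nc4ccc(F)c(Cl)c4)ncnc3cc2OC)CC1` differs from compound 3 by butyl in place of hydrogen on a saturated chain carbon, eight bonds along the chain from an oxygen next to a carbonyl group. The three chain extensions already measured bear on this change, and none of them moved the read-out beyond the scatter, so no step beyond the scatter in this assay is expected; the estimated step reads a number 0.3 percentage points higher from compound 3 to compound 4 (within the scatter). Compound 4 is therefore expected to give 22%, estimated between 12% and 32%.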

Compound 4, a percentage reported as activity, at one concentration (the size of the read-out at that concentration, not a potency): 2.3%
Beside the measured number, compound 4's estimate is 19.7 percentage points above it; the measured number lies below the stated range.
By their numbers in this assay, from the lowest: compound 4; then compounds 2, 3 and 1 (each within the scatter of the next).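

In this assay, the chain at this place had shown no step beyond the scatter until butyl entered eight bonds along the chain from an oxygen next to a carbonyl group: a number 19.4 percentage points lower from compound 3 to compound 4 (beyond the scatter), alongside a number 15.9 percentage points lower from compound 2 to compound 4 (beyond the scatter) and a number 21.1 percentage points lower from compound 1 to compound 4 (beyond the scatter). The read-out therefore does respond to chain length here, but among these four compounds only compound 4 stands apart, with a stronger effect than compounds 1, 2 and 3. Nothing available explains this drop. On these data alone, whether decyl already gives the stronger effect, or a chain longer than that of compound 4 keeps it, remains open. So does the outcome with an amine or a carboxylic acid in place of the chain.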